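The source may report more compounds than this note shows. Statements on the series, on what has been measured and on what is new or still open speak of the compounds shown alone.

In a functional assay on Right cardiac atrium for agonist activity at histamine H2 receptor (Cavia porcellus), with a stated time of 30 min, in the presence of a further agent that is not named here (a lower number here means a smaller maximal response, a higher number a larger maximal response), three compounds have been measured so far:
compound 1 `Cc1nc(N)sc1CCCN/C(N)=N/C(=O)N[C@H](C)c1ccccc1` gives 0.95;
compound 2 `Cc1nc(N)sc1CCCN/C(N)=N/C(=O)NC(C)c1ccccc1F` gives 0.93;
compound 3 `Cc1nc(N)sc1CCCN/C(N)=N/C(=O)NC(C)c1ccc(F)cc1` gives 0.92.

All three share the same core and differ only in the aromatic ring carried on the saturated chain carbon bound to an amide-type nitrogen. Compound 3 has the lowest of the three numbers, but compound 2 stands nearest to it and compound 1 furthest, and neither gap is beyond the scatter, so the three cannot be told apart on maximal response.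

Compound 4 `Cc1nc(N)sc1CCCN/C(N)=N/C(=O)NC(C)c1cccs1` has not yet been measured. (thiophen-2-yl in place of 4-fluorophenyl on a saturated chain carbon bound to an amide-type nitrogen and a saturated chain carbon). Among the measured compounds shown here, the only step measured in one place, a number 0.010 lower from compound 2 to compound 3 (within the scatter), moved the fluorine from one position of the phenyl ring to another and left the maximal response unchanged beyond the scatter. For the measured compounds named here, no measured step exchanges a six-membered ring for a five-membered one, so the expectation for compound 4 rests only on the fact that every ring tried so far gives close to the full response. A step of a number 0.010 higher from compound 3 to compound 4 (within the scatter) is therefore expected, which is no change beyond the scatter. Compound 4 is estimated at 0.93, with a range from 0.84 to 1.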

Compound 4, intrinsic activity: the largest response reached, as a fraction of the reference agonist's: 0.88
Compound 4: middle estimate off by 0.050, on the high side; the measured number falls inside the stated range.
By their numbers in this assay, from the lowest: compounds 4, 3, 2 and 1 (each within the scatter of the next).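

In this assay, among the compounds shown here, thiophen-2-yl brings a five-membered aromatic ring with 1 hetero atom to the place on a saturated chain carbon bound to an amide-type nitrogen and a saturated chain carbon, where the earlier compounds all carried a six-membered aromatic ring of carbon only, and the exchange for 4-fluorophenyl gives a number 0.040 lower from compound 3 to compound 4 (within the scatter) on the maximal response. The same reading holds against the other two rings, with a number 0.050 lower from compound 2 to compound 4 (within the scatter) for the exchange of 2-fluorophenyl and a number 0.070 lower from compound 1 to compound 4 (within the scatter) for the exchange of 1-phenylethyl, so this position accepts a smaller ring holding sulfur, and no fluorine, with no change beyond the scatter in any of the three comparisons. Nothing available here explains how this ring exchange acts on the response.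

The compounds shown leave open whether thiophen-3-yl, furan-2-yl, pyridin-2-yl or cyclohexyl at this place would also stay within the scatter of these four. They also leave open whether any ring is needed at all, which a plain methyl group in place of the ring would test.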